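The source may hold more compounds than are shown below. What is called first, only, known or untested is meant among the compounds shown, and "the series" means these compounds.

Measured so far in an assay on microsomes from liver for inhibition of 3-hydroxy-3-methylglutaryl-coenzyme A reductase (Rattus norvegicus); on this read-out higher numbers stand for weaker inhibition and lower numbers for stronger inhibition:
compound 1 `O=C(O)C[C@H](O)C[C@H](O)CCn1c(C(F)(F)F)nc(-c2ccc(F)cc2)c1-c1cccc(Cl)c1` — compound 1 gives 41 nM
compound 2 `Cc1cc(-c2c(-c3ccc(F)cc3)nc(C(F)(F)F)n2CC[C@@H](O)C[C@@H](O)CC(=O)O)cc(C)c1F` — compound 2 gives 31 nM

Of the two numbers, compound 2 carries the smaller, but the gap between them is a 1.3-fold lower number from compound 1 to compound 2 (0.12 log units; within the scatter), so no order between the two is claimed. That step, 4-fluoro-3,5-dimethylphenyl in place of 3-chlorophenyl on an aromatic carbon, is the only one in hand at this position of the shared core.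

Compound 3 `O=C(O)C[C@H](O)C[C@H](O)CCn1c(C(F)(F)F)nc(-c2ccc(F)cc2)c1-c1cccnc1` is not yet measured. It differs from compound 2 by pyridin-3-yl in place of 4-fluoro-3,5-dimethylphenyl on an aromatic carbon. Within the data shown here, the one measured step that bears on this change is the aryl exchange at the same position, which was a 1.3-fold lower number from compound 1 to compound 2 (0.12 log units; within the scatter). Among the measured compounds shown here, no measured compound carries a pyridin-3-yl here, so the expectation rests on that single swap alone. For compound 3 the expected step in this assay is a 1.9-fold higher number from compound 2 to compound 3 (0.29 log units; within the scatter), not beyond the scatter. Compound 3 is estimated at 60 nM, range 20 nM to 180 nM.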

Compound 3, half-maximal inhibitory concentration: > 1000 nM
Compound 3: a limit, no number (the forecaster's own chance of this, stated with the estimate: 3%); at least 16-fold (1.22 log units) between middle value and limit.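

In this assay compound 3 sits at a limit of the assay and not at a number: the limit of > 1000 nM in this assay, at which 1 of the 3 values shown sits.

The earlier aryl exchange at this position gave no step beyond the scatter, but this position does not accept every aryl group alike: pyridin-3-yl gives an at least 32-fold higher number from compound 2 to compound 3 (1.50 log units; beyond the scatter) and an at least 24-fold higher number from compound 1 to compound 3 (1.38 log units; beyond the scatter). Among the three compounds, the two aryl rings of carbon only, each with substituents, carry measured numbers, while the unsubstituted ring with one hetero atom carries the limit.

The compounds shown do not separate the hetero atom from the absence of substituents on the ring; an unsubstituted phenyl or a 3-chlorophenyl analogue with a ring nitrogen would bear on that. As far as these compounds go, the true size of both steps also stays open, since the value of compound 3 is a limit.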